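Adding a third methoxy to compound 3

The source may report more compounds than this note shows. Statements on the series, on what has been measured and on what is new or still open speak of the compounds shown alone.

The series shares one core, shown with compound 1 `Nc1cc(N)c2nc(-c3ccccc3)c(Oc3ccc(Cl)c(Cl)c3)nc2c1`. In a functional assay on SK-MEL-2 cells (Homo sapiens) for inhibition, read by sulforhodamine B assay, with a stated time of 48 h (a higher number here means a weaker inhibitor of growth, a lower number a stronger inhibitor of growth), compound 1 gives 23400 nM. Compound 2 `Nc1cc(N)c2nc(-c3ccccc3)c(NCc3ccc(Cl)c(Cl)c3)nc2c1` gives 4270 nM in this assay. Compound 3 `COc1ccc(CNc2nc3cc(N)cc(N)c3nc2-c2ccccc2)cc1OC` gives 30200 nM in this assay. Among the three numbers, compound 3 carries the highest; compound 1 sits within the scatter of it, so no order between those two is claimed, whereas the step of a 7.1-fold higher number from compound 2 to compound 3 (0.85 log units; beyond the scatter) lies beyond the scatter.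

Compound 4 `COc1cc(CNc2nc3cc(N)cc(N)c3nc2-c2ccccc2)cc(OC)c1OC` differs from compound 3 by methoxy in place of hydrogen on an aromatic carbon. For the measured compounds named here, only one measured step touches this part of the molecule, a 7.1-fold higher number from compound 2 to compound 3 (0.85 log units; beyond the scatter), and that step swaps the whole substituted ring rather than adding a single methoxy to a ring that already carries two; no measured pair shows the effect of such an addition. The step from compound 2 to compound 3 is therefore background, not a direct precedent, and on the evidence here the change is expected to move this assay by no step beyond the scatter, in either direction.

Compound 4 is accordingly expected to give about 30000 nM, within 12000 nM to 75000 nM, a step of a 1.0-fold lower number from compound 3 to compound 4 (0.00 log units; within the scatter) that is expected to stay within the scatter.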

Compound 4, concentration for total growth inhibition: < 50200 nM
Compound 4 ended at the assay's limit; the forecaster's own chance of this, stated with the estimate: 15%; the middle value is on the limit's open side.
By their numbers in this assay, from the lowest: compound 2; then compounds 1 and 3 (each within the scatter of the next).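

In this assay compound 4 gives < 50200 nM, which is a limit of the assay and not a number. The step from compound 3 to compound 4 therefore cannot be read. The compounds shown leave open what methoxy in place of hydrogen on this aromatic ring does to the growth-inhibition read-out.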